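A few compounds are considered here, and "the series" means these few. Any claim that something is new, unique, unknown or untested is made for them only; others in the source may bear on it.

In a functional assay on A549 cells (Homo sapiens) for antiproliferative activity, read by sulforhodamine B assay, with a stated time of 48 h (on this read-out higher numbers stand for weaker inhibition and lower numbers for stronger inhibition), compound 1 (`COc1ccc(-c2ccccc2C(=O)/C=C/c2ccc(F)cc2)cc1OC`) gives 8600 nM. Compound 2 (`COc1ccc(/C=C/C(=O)c2ccccc2-c2ccc(F)cc2)cc1`) gives 140 nM, and compound 3 (`COc1ccc(/C=C/C(=O)c2ccccc2-c2cccc(F)c2)cc1`) gives 280 nM, so compound 3 stands close to compound 2 and far under compound 1. Compound 4 (`COc1ccc(/C=C/C(=O)c2ccccc2-c2ccc(F)nc2)cc1`) differs from compound 3 in one group: 6-fluoropyridin-3-yl in place of 3-fluorophenyl on an aromatic carbon. Going by the values given here, the only measured step that bears on this change swaps 4-fluorophenyl for 3-fluorophenyl, a 2.0-fold higher number from compound 2 to compound 3 (0.30 log units; within the scatter). Both of those groups keep a ring of carbon only, so this step is a weak guide to the new ring with its hetero atom. No step beyond the scatter is therefore expected in this assay. The expected change is a 1.4-fold higher number from compound 3 to compound 4 (0.15 log units; within the scatter). For compound 4 the estimate is 400 nM, with an expected range from 130 nM to 1300 nM.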

Compound 4, half-maximal inhibitory concentration: 930 nM
Compound 4: middle estimate off by 2.3-fold (0.37 log units), on the low side, and the stated range covers the measured number.
By their numbers in this assay, from the lowest: compounds 2 and 3 (each within the scatter of the next); then compound 4; then compound 1.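

Going by these compounds alone, replacing the carbon-only ring with 6-fluoropyridin-3-yl is the first change at this position to go beyond the scatter, giving a 3.3-fold higher number from compound 3 to compound 4 (0.52 log units; beyond the scatter) and a 6.6-fold higher number from compound 2 to compound 4 (0.82 log units; beyond the scatter). The position therefore responds to a nitrogen in the attached ring, and the response is modest. Nothing here gives a measured reason for this. Going by these compounds, it remains open whether the same ring without its fluorine would behave alike, and how a ring carrying an amine in place of the fluorine would compare.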